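Thiocarbonyl Series: Swapping Isopropyl for 1-Methylcyclopropyl

The source may report more compounds than this note shows. Statements on the series, on what has been measured and on what is new or still open speak of the compounds shown alone.

Compound 3 `Cc1nc(S(C)(=O)=O)ccc1Oc1ncnc(OC2CCN(C(=S)OC(C)C)CC2)c1F` is the weakest of the three compounds measured in a functional assay on isolated protein for inhibition of Glucose-dependent insulinotropic receptor (Rattus norvegicus), read by HTRF and cAMP accumulation (a higher number here means a larger maximal response, a lower number a smaller maximal response), giving 47%. Compound 1 `Cc1nc(S(C)(=O)=O)ccc1Oc1ncnc(OC2CCN(C(=O)OC3CCC3)CC2)c1F` gives 81% and compound 2 `Cc1nc(S(C)(=O)=O)ccc1Oc1ncnc(OC2CCN(C(=O)OC3(C(F)(F)F)COC3)CC2)c1F` gives 84%. The steps of a number 34 percentage points lower from compound 1 to compound 3 (beyond the scatter) and a number 37 percentage points lower from compound 2 to compound 3 (beyond the scatter) both replaced the carbonyl-bearing group on the ring nitrogen with the thiocarbonyl-bearing one. Compound 4 `Cc1nc(S(C)(=O)=O)ccc1Oc1ncnc(OC2CCN(C(=S)OC3(C)CC3)CC2)c1F` keeps that thiocarbonyl and differs from compound 3 only by 1-methylcyclopropyl in place of isopropyl on an oxygen on an unsaturated carbon. Among the compounds with values here, the nearest precedent is a number 3 percentage points higher from compound 1 to compound 2 (within the scatter), where the group on the oxygen was exchanged while the rest stayed fixed, and the response barely moved. The analogous exchange here is therefore expected to produce no step beyond the scatter, a number 3 percentage points higher from compound 3 to compound 4 (within the scatter). Compound 4 is estimated at 50%, with a range of 35% to 65%.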

Compound 4, largest response reached (reported as efficacy), in percent of the reference or control that the assay uses: 49%
Estimate against measurement, compound 4: 1 percentage points above, and the stated range covers the measured number.
By their numbers in this assay, from the lowest: compounds 3 and 4 (each within the scatter of the next); then compounds 1 and 2 (each within the scatter of the next).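

In this assay the move from isopropyl to 1-methylcyclopropyl gives a number 2 percentage points higher from compound 3 to compound 4 (within the scatter) and so shows that the thiocarbonyl compounds, like the carbonyl pair, take a new group on this oxygen with no clear change. The lower response remains with the new group, seen as a number 32 percentage points lower from compound 1 to compound 4 (beyond the scatter) and as a number 35 percentage points lower from compound 2 to compound 4 (beyond the scatter) when set against the carbonyl compounds. No measurement at hand explains these results. Still open, going by these compounds, is whether a phenyl ring or a longer chain such as n-butyl on this oxygen would lift the thiocarbonyl compounds.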